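Working notes: aryl replacement on the compound 2 scaffold

The compounds below may be only part of what the source reports. "The series", "measured", "known", "first", "only" and "open" are said of these compounds alone.

Measured so far:
compound 1, `Cn1c(Cc2cccc(C#N)c2)nc2cc(O[C@H]3CC[C@@H](C(=O)O)CC3)ccc21`, 22000 nM
compound 2, `Cc1cccc(Cc2nc3cc(O[C@H]4CC[C@@](F)(c5nnn[nH]5)CC4)ccc3n2C)c1`, 13 nM

The read-out is an assay on isolated protein for inhibition of Long-chain-fatty-acid--CoA ligase 1 (Mus musculus), read by mass spectrometry, with a stated time of 90 min, in the presence of a further agent that is not named here; on this read-out higher numbers stand for weaker inhibition and lower numbers for stronger inhibition. Among the measured compounds shown here, compound 2 holds the lowest number of the two; its only neighbour, compound 1, sits far higher, a gap beyond the scatter.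

Compound 3, `Cn1c(Cc2ccc3c(c2)OCC3)nc2cc(O[C@H]3CC[C@@](F)(c4nnn[nH]4)CC3)ccc21`, is not yet measured. It differs from compound 2 by a group of 9 heavy atoms (8 carbon, 1 oxygen; one five-membered non-aromatic ring with 1 hetero atom, one six-membered aromatic ring of carbon only) in place of a group of 7 heavy atoms (7 carbon; one six-membered aromatic ring of carbon only), on a saturated chain carbon bound to an aromatic carbon. For the measured compounds named here, no measured pair shows this change, so no direction is supported by data; a small move toward a higher number, near the scatter, is expected. Compound 3 is expected at 25 nM, within 6 nM to 120 nM. That estimate amounts to an expected step of a 1.9-fold higher number from compound 2 to compound 3 (0.28 log units; within the scatter).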

Compound 3, half-maximal inhibitory concentration: 15 nM
Compound 3: the middle estimate sits 1.7-fold (0.22 log units) above what was measured, within the range that was stated.
By their numbers in this assay, from the lowest: compounds 2 and 3 (each within the scatter of the next); then compound 1.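

In this assay, exchanging 3-methylphenyl for the oxygen-containing two-ring group, on a saturated chain carbon bound to an aromatic carbon, gives a 1.2-fold higher number from compound 2 to compound 3 (0.06 log units; within the scatter). This position therefore accepts a group of 9 heavy atoms with a hydrogen-bond acceptor, with no change beyond the scatter, something compound 1 and compound 2 could not show because they differ in more than one place. No measurement available here explains this tolerance.

Going by these compounds, whether an amine or a longer chain would also be accepted at this position remains open. The large gap to compound 1 also stays unassigned to any single change.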